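Bromo for methyl on the benzyl ether of the sulfonate series

This account rests on a few compounds, and the source may have more. Where it says the series, first, only, none or still open, it means among the compounds named here.

The series shares a cyclic sulfonate core carrying a benzyl ether; two members have been measured so far in an ADME assay on HEL cells (Homo sapiens) for cytotoxicity, with a stated time of 3 days; a lower number here means that less compound is tolerated, a higher number that more compound is tolerated. Compound 1 `CCC1(Cc2ccccc2)OS(=O)(=O)C=C1OCc1ccc(C)cc1` is the compound with the lowest number of the two: in this assay compound 1 gives 41500 nM. Compound 2 `CC1(C(c2ccccc2)c2ccccc2)OS(=O)(=O)C=C1OCc1ccccc1` differs from compound 1 at more than one place. In this assay compound 2 gives a higher number, 200000 nM, and that gap lies beyond the scatter. Among the compounds with values here, no single-change step between measured compounds is available, so the size of any one change cannot be read from the numbers yet.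

Compound 3 `CCC1(Cc2ccccc2)OS(=O)(=O)C=C1OCc1ccc(Br)cc1` is the next member to be measured. Compared with compound 1 it shows bromo in place of methyl on an aromatic carbon of a six-membered aromatic ring of carbon only, with the benzyl ether otherwise unchanged. For a change of this kind on the outer ring, only a small step is expected in this assay, probably not beyond the scatter, with a slight lean toward a lower number. The step from compound 1 to compound 3 is estimated at a 1.4-fold lower number from compound 1 to compound 3 (0.14 log units; within the scatter). Compound 3 is therefore expected to give 30000 nM in this assay, in the range from 12000 nM to 90000 nM.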

Compound 3, half-maximal cytotoxic concentration: 171000 nM
Estimate against measurement, compound 3: 5.7-fold (0.76 log units) below; the whole stated range lies below it.
By their numbers in this assay, from the lowest: compound 1; then compounds 3 and 2 (each within the scatter of the next).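

In this assay, within the data shown here, this exchange gives the first reading of a single change: 4-methylbenzyl to 4-bromobenzyl, with the rest of compound 1 untouched, gives a 4.1-fold higher number from compound 1 to compound 3 (0.61 log units; beyond the scatter) and so lies beyond the scatter. The position para to a large group on this aromatic ring is therefore not silent, even though one heavy atom simply replaces another and the counts of hydrogen-bond donors, hydrogen-bond acceptors and net charge stay the same. No accompanying measurement bears on the origin of this step.

Compound 2 differs from compound 1 and compound 3 in more than one place, so steps to it cannot be read, and its unsubstituted benzyl ether gives no clean reference for this position. The compounds shown also leave open whether a methoxy group, a nitrile, a chloro group or an amine at this same position would move the number as bromo does, and whether the step from methyl to bromo would hold on a core carrying a different side chain from that of compound 1.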